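A few compounds are considered here, and "the series" means these few. Any claim that something is new, unique, unknown or untested is made for them only; others in the source may bear on it.

Going by the values given here, in a functional assay on HCT-116 cells (Homo sapiens), read by MTT assay, with a stated time of 72 h (on this read-out higher numbers stand for weaker inhibition and lower numbers for stronger inhibition), compound 1 `CNc1ncnc2c1c(-c1ccco1)cn2[C@@H]1O[C@H](CO)[C@@H](O)[C@H]1O` gives 230 nM, the only number so far. Compound 2 `Nc1nc(N)c2c(-c3ccsc3)cn([C@@H]3O[C@H](CO)[C@@H](O)[C@H]3O)c2n1` reads > 20000 nM, which is a limit of the assay. Compound 3 `Nc1nc(N)c2c(-c3cc4ccccc4o3)cn([C@@H]3O[C@H](CO)[C@@H](O)[C@H]3O)c2n1` reads > 20000 nM, also a limit. Compound 1 therefore stands alone, with the rest at the limit of > 20000 nM in this assay, at which 2 of the 3 values shown sit.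

Next is compound 4 `CNc1ncnc2c1c(I)cn2[C@@H]1O[C@H](CO)[C@@H](O)[C@H]1O`, with the change iodo in place of furan-2-yl on an aromatic carbon. Among the compounds with values here, the one measured step, a step that the two limits leave unreadable from compound 2 to compound 3, concerns other groups on a different core and gives no size. With compound 1 at 230 nM as the only anchor, weaker inhibition in this assay is tentatively expected. The expected change is a 6.5-fold higher number from compound 1 to compound 4 (0.81 log units; beyond the scatter). For compound 4 the estimated value is 1500 nM, within an expected range of 150 nM to 15000 nM.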

Compound 4, half-maximal inhibitory concentration: > 100000 nM
Compound 4: only a limit was reported; the forecaster's own chance of this, stated with the estimate: 20%; middle value at least 66-fold (1.82 log units) from the limit.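

In this assay, going by these compounds alone, iodo in place of furan-2-yl gives an at least 430-fold higher number from compound 1 to compound 4 (2.63 log units; beyond the scatter), the first readable step, showing that on the core of compound 1 the group on this aromatic carbon strongly affects the read-out. As far as these compounds go, compound 4 reads > 100000 nM, which is a limit of the assay, so the full size of the step remains unknown. The step between the two limits of compound 2 and compound 3 cannot be read.

This single pair does not separate the loss of the furan ring from the entry of iodine. From the compounds shown here alone, whether phenyl, a methyl group or an amine on this carbon would retain activity remains open.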